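Chloro for fluoro on the urea-bearing phenyl ring

A few compounds are considered here, and "the series" means these few. Any claim that something is new, unique, unknown or untested is made for them only; others in the source may bear on it.

Of the compounds shown here, two have been measured in a functional assay on HT-29 cells (Homo sapiens) for cytotoxicity, read by MTT assay, with a stated time of 72 h; on this read-out higher numbers stand for weaker inhibition and lower numbers for stronger inhibition. Compound 1, `CN(C)CCCNc1nc(-c2ccc(NC(=O)Nc3ccccc3F)cc2)nc2ccsc12`, gives 470 nM in this assay. Compound 2, `CN(C)CCCNc1nc(-c2ccc(NC(=O)Nc3ccc(F)cc3)cc2)nc2c(Cl)c(Cl)sc12`, gives 430 nM in this assay. Compound 1 has the higher of the two numbers, but compound 2 sits within the usual scatter of it, so the two values show no difference that can be read as a change. Within the data shown here, no single-point step between measured compounds is available.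

Compound 3, `CN(C)CCCNc1nc(-c2ccc(NC(=O)Nc3ccccc3Cl)cc2)nc2ccsc12`, differs from compound 1 by chloro in place of fluoro on an aromatic carbon, ortho to a large group. Among the measured compounds shown here, with no measured step of this kind to lean on, the expected change from compound 1 to compound 3 is a 1.1-fold lower number from compound 1 to compound 3 (0.05 log units; within the scatter), which is not expected to exceed the scatter in either direction. Compound 3 is therefore estimated to give 420 nM in this assay, with a likely range from 150 nM to 1200 nM.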

Compound 3, half-maximal inhibitory concentration: 390 nM
The estimate for compound 3 lay 1.1-fold (0.03 log units) above the measured number; measured number inside the range.
By their numbers in this assay, from the lowest: compounds 3, 2 and 1 (each within the scatter of the next).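

The series now has its first step at a single place: in this assay, replacing 2-fluorophenyl with 2-chlorophenyl gives a 1.2-fold lower number from compound 1 to compound 3 (0.08 log units; within the scatter). At this place on the ring, ortho to a large group, chloro and fluoro therefore cannot be told apart on this read-out, something the earlier pair could not show, as those two compounds differ in more than one place. No measurement at hand bears on why the two groups read alike.

The compounds shown leave open whether a methoxy group, a trifluoromethyl group or an amine at this place would also stay within the scatter of these values. They also leave open whether chloro in place of fluoro would read the same way on a different core.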